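Cytotoxicity notes: furan to fluoromethoxyphenyl at the amine end

A few compounds are considered here, and "the series" means these few. Any claim that something is new, unique, unknown or untested is made for them only; others in the source may bear on it.

Measured compounds in an ADME assay on HepG2 cells (Homo sapiens) for cytotoxicity, read by luminescence, CellTiter-Glo and ATP content, with a stated time of 72 h; a lower number here means that less compound is needed, a higher number that more compound is needed for the effect:
compound 1 `COc1ccc(F)cc1CNCCCNc1ccnc2cc(Cc3ccc(F)cc3Cl)ccc12`: 2460 nM
compound 2 `COc1ccc(F)cc1CNCCCNc1ccnc2cc(Oc3ccc(F)cc3)ccc12`: 6600 nM
compound 3 `CC(C)(C)c1ccc(-c2ccc3c(NCCCNCc4ccco4)ccnc3c2)cc1`: 3150 nM

Compound 3 stands second highest of the three numbers. Its nearest neighbour is compound 1, a difference within the scatter, so the two cannot be ranked; its furthest is compound 2, a gap beyond the scatter.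

The unmeasured compound 4 `COc1ccc(F)cc1CNCCCNc1ccnc2cc(-c3ccc(C(C)(C)C)cc3)ccc12` is reached from compound 3 by one change: 5-fluoro-2-methoxyphenyl in place of furan-2-yl on a saturated chain carbon bound to an amine nitrogen. Compound 4 shares this 5-fluoro-2-methoxybenzyl end with compound 1 and compound 2, and shares the core of compound 3 otherwise.

Among the compounds with values here, the only measured step, a 2.7-fold higher number from compound 1 to compound 2 (0.43 log units; beyond the scatter), alters the group on an aromatic carbon of the core, not the chain end, so it does not bear on this change. Within the data shown here, no measured pair shows the furan-2-yl to 5-fluoro-2-methoxyphenyl swap. What can be said is that compound 1 and compound 2, which both carry the entering group, give values that bracket compound 3. Among the measured compounds shown here, with no step on record for the change, no move beyond the scatter is expected in this assay.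

Compound 4 is therefore estimated at 3500 nM, with a range from 1500 nM to 8000 nM. The expected step is a 1.1-fold higher number from compound 3 to compound 4 (0.05 log units; within the scatter), within the scatter.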

Compound 4, half-maximal effective concentration: 620 nM
The estimate for compound 4 lay 5.6-fold (0.75 log units) above the measured number; measured number below the stated range.
By their numbers in this assay, from the lowest: compound 4; then compounds 1 and 3 (each within the scatter of the next); then compound 2.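

In this assay, within the data shown here, the chain end proves not to be silent: 5-fluoro-2-methoxyphenyl in place of furan-2-yl, on a saturated chain carbon bound to an amine nitrogen, gives a 5.1-fold lower number from compound 3 to compound 4 (0.71 log units; beyond the scatter) on the first reading of this change. With the 5-fluoro-2-methoxybenzyl end held fixed, the group on the aromatic carbon also counts, since 4-(tert-butyl)phenyl gives a 4.0-fold lower number from compound 1 to compound 4 (0.60 log units; beyond the scatter) in place of 2-chloro-4-fluorobenzyl and an 11-fold lower number from compound 2 to compound 4 (1.03 log units; beyond the scatter) in place of 4-fluorophenoxy. The entering end does not set a low number on its own. Compound 1 and compound 2 carry it too and still read higher; of the compounds shown, only compound 4, which joins that end to 4-(tert-butyl)phenyl, lies beyond the scatter below all the others.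

On these data alone, whether the furan-2-yl swap keeps this size on the substituted cores of compound 1 and compound 2 stays open, as does how an unsubstituted benzyl or a pyridin-2-ylmethyl at the chain end, or a longer chain, would read. No measurement at hand explains any of these steps.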